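This account rests on a few compounds, and the source may have more. Where it says the series, first, only, none or still open, it means among the compounds named here.

Measured compounds:
Compound 1 `COc1cc(C2CC(c3ccc(OCc4cn(Cc5ccc([N+](=O)[O-])cc5)nn4)cc3)=NN2C(C)=O)ccc1Oc1cn(Cc2ccc([N+](=O)[O-])cc2)nn1` gives 51% in a functional assay on COLO 205 cells (Homo sapiens) for inhibition, read by sulforhodamine B assay, tested at 100 uM; a lower number here means less inhibition of growth, a higher number more inhibition of growth at the concentration tested.
Compound 2 `COc1cc(C2CC(c3ccccc3)=NN2C(C)=O)ccc1OCc1cn(Cc2ccc([N+](=O)[O-])cc2)nn1` gives 11% in this assay.

Compound 2 stands lowest of the two numbers; its nearest neighbour is compound 1, whose value lies a full step higher, beyond the scatter. The account now follows compound 2 to compound 3 `COc1cc(C2CC(c3ccc(Cl)cc3)=NN2C(C)=O)ccc1OCc1cn(Cc2ccc([N+](=O)[O-])cc2)nn1`, where the change is chloro in place of hydrogen on an aromatic carbon. Within the data shown here, no measured pair shows this kind of change, so the size of the step in this assay is uncertain; a small rise at most is anticipated, possibly none beyond the scatter. The estimate for compound 3 is 18%, with a range from 5% to 35%, so that the expected step is a number 7 percentage points higher from compound 2 to compound 3 (within the scatter).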

Compound 3, percent growth inhibition at one concentration: 10%
For compound 3 the middle estimate is 8 percentage points above the measured one; low and high end bracket the measured number.
By their numbers in this assay, from the lowest: compounds 3 and 2 (each within the scatter of the next); then compound 1.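

In this assay, among these compounds, phenyl to 4-chlorophenyl gives a number 1 percentage points lower from compound 2 to compound 3 (within the scatter), the first reading of a change at this position. On this six-membered aromatic ring, para to a large group, a single chloro in place of hydrogen therefore produces no difference beyond the scatter at the concentration tested. Nothing available explains this result. Still open, going by these compounds, is whether an amine or a carboxylic acid at this same position would also stay within the scatter of compound 2. On these data alone, the effect of chloro elsewhere on this ring also remains open.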